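A few compounds are considered here, and "the series" means these few. Any claim that something is new, unique, unknown or untested is made for them only; others in the source may bear on it.

For the measured compounds named here, compound 1 `NS(=O)(=O)c1ccc(N2N=C(c3ccc(Oc4ccccc4)cc3)CC2c2ccc(Cl)cc2)cc1` gives 7000 nM in an ADME assay on BHK-21 cells (Mesocricetus auratus) for cytotoxicity, read by MTT assay, with a stated time of 72 h (a higher number here means that more compound is tolerated, a lower number that less compound is tolerated), the lowest of the three numbers measured so far. Compound 3 `NS(=O)(=O)c1ccc(N2N=C(c3ccc(OCc4ccccc4)cc3)CC2c2ccc(Cl)cc2)cc1` gives 15000 nM in this assay, and compound 2 `NS(=O)(=O)c1ccc(N2N=C(c3ccc(OCc4ccccc4)cc3)CC2c2ccccc2)cc1` gives 80000 nM. The two measured steps concern other changes: a 2.1-fold higher number from compound 1 to compound 3 (0.33 log units; beyond the scatter) for benzyl in place of phenyl on an oxygen on an aromatic ring, and a 5.3-fold lower number from compound 2 to compound 3 (0.73 log units; beyond the scatter) for chloro in place of hydrogen on an aromatic carbon. Compound 4 `Cc1ccc(C2CC(c3ccc(Oc4ccccc4)cc3)=NN2c2ccc(S(N)(=O)=O)cc2)cc1` differs from compound 1 in one place: methyl in place of chloro on an aromatic carbon. Going by the values given here, no measured step replaces chloro with methyl, so nothing bears on it directly. The closest guide is a 5.3-fold lower number from compound 2 to compound 3 (0.73 log units; beyond the scatter), which shows that the chloro at this place goes with a lower number than hydrogen; compound 4 keeps a group of one heavy atom at that place rather than removing it, so at most a modest rise is anticipated. Compound 4 is therefore expected to give 10000 nM, between 4000 nM and 25000 nM. That corresponds to an expected step of a 1.4-fold higher number from compound 1 to compound 4 (0.15 log units; within the scatter), which may sit within the scatter.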

Compound 4, half-maximal cytotoxic concentration: 8000 nM
Estimate against measurement, compound 4: 1.3-fold (0.10 log units) above, within the range that was stated.
By their numbers in this assay, from the lowest: compounds 1, 4 and 3 (each within the scatter of the next, the first and the last beyond it); then compound 2.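

In this assay, going from 4-chlorophenyl to 4-methylphenyl gives a 1.1-fold higher number from compound 1 to compound 4 (0.06 log units; within the scatter), so on this aromatic carbon, para to a large group, the two groups are not told apart. The earlier compounds shown here showed only that chloro differs from hydrogen at this place, with a 5.3-fold lower number from compound 2 to compound 3 (0.73 log units; beyond the scatter); this result adds that a methyl, with the same count of one heavy atom, does not recover the higher number seen with hydrogen in compound 2. No measurement shown here accounts for this result.

The compounds shown leave open whether hydrogen at this place would also raise the number in compounds with phenyl on the oxygen. They also leave open how a methoxy group, an amine or a carboxylic acid would behave at this place.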